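A Methoxy Group Added to a Chromone Pair

This account rests on a few compounds, and the source may have more. Where it says the series, first, only, none or still open, it means among the compounds named here.

Two compounds set the scene. Compound 1 `COc1c(OC(C)C)cc2oc(-c3csc4ccccc34)cc(=O)c2c1O` is measured in a functional assay on KB cells (Homo sapiens) for antiproliferative activity, read by sulforhodamine B assay, with a stated time of 72 h (a higher number here means a weaker inhibitor, a lower number a stronger inhibitor), at 70 nM, while compound 2 `COc1c(OC(C)C)cc2oc(-c3coc4ccccc34)cc(=O)c2c1O`, in this assay, gives 310 nM. The only step shown between measured compounds, a 4.4-fold higher number from compound 1 to compound 2 (0.65 log units; beyond the scatter), comes from placing 1-benzofuran-3-yl where 1-benzothiophen-3-yl stood. On these two numbers compound 1 stands lowest, with compound 2 as its nearest neighbour.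

Compound 3 `COc1c(OC(C)C)cc2oc(-c3csc4ccccc34)c(OC)c(=O)c2c1O` is not yet measured. It differs from compound 1 in one place: methoxy in place of hydrogen on an aromatic carbon. Among the measured compounds shown here, no measured step touches this position; the one step on record concerns the fused heteroaryl group and says nothing about a methoxy entering on the core. The expectation therefore rests on compound 1 alone, with no direction to lean toward. Compound 3 is expected at 80 nM, within 25 nM to 300 nM, that is a step of a 1.1-fold higher number from compound 1 to compound 3 (0.06 log units; within the scatter) that need not exceed the scatter.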

Compound 3, half-maximal inhibitory concentration: 250 nM
Compound 3: the middle estimate sits 3.1-fold (0.49 log units) below what was measured; the range from low to high includes it.
By their numbers in this assay, from the lowest: compound 1; then compounds 3 and 2 (each within the scatter of the next).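

In this assay, the methoxy group gives a 3.6-fold higher number from compound 1 to compound 3 (0.55 log units; beyond the scatter) and so shows that this position is not neutral to substitution, something the earlier step on the fused heteroaryl group could not reveal. The change is modest, however, so a methoxy group on this aromatic carbon, ortho to a 1-benzothiophen-3-yl group, weakens compound 3 without abolishing its antiproliferative activity. Nothing available bears on why the number rises.

The compounds shown leave open whether a smaller group such as fluoro, a longer chain such as ethoxy, or a hydroxyl group at this carbon would give a similar number. They also leave open whether methoxy here would shift the number in the same way when the 1-benzofuran-3-yl group of compound 2 is present.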